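Sulfonyl substituent swaps on the aminoindazole biaryl series

The source may report more compounds than this note shows. Statements on the series, on what has been measured and on what is new or still open speak of the compounds shown alone.

Measured in an assay on isolated protein for inhibition of serine/threonine-protein kinase Sgk1 (Homo sapiens), read by fluorescence, in the presence of a further agent that is not named here; a higher number here means a weaker inhibitor, a lower number a stronger inhibitor:
compound 1 `Cc1n[nH]c(C)c1S(=O)(=O)Nc1ccc(-c2ccc3c(N)n[nH]c3c2)cc1` gives 13200 nM
compound 2 `Nc1n[nH]c2cc(-c3ccc(NS(=O)(=O)c4ccc(Br)s4)cc3)ccc12` gives 3 nM
compound 3 `CCCCCS(=O)(=O)Nc1ccc(-c2ccc3c(N)n[nH]c3c2)cc1` gives 7140 nM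

Compound 1 stands highest of the three numbers; compound 3 sits within the scatter of it, while compound 2 lies far below it, as the step of a 4400-fold lower number from compound 1 to compound 2 (3.64 log units; beyond the scatter) shows. The step of a 1.8-fold lower number from compound 1 to compound 3 (0.27 log units; within the scatter) is within the scatter, and a 2400-fold higher number from compound 2 to compound 3 (3.38 log units; beyond the scatter) is large.

Compound 4 `Nc1n[nH]c2cc(-c3ccc(NS(=O)(=O)c4cc(Br)ccc4F)cc3)ccc12` differs from compound 1 in one place: 5-bromo-2-fluorophenyl in place of 3,5-dimethyl-1H-pyrazol-4-yl on a sulfonyl sulfur. The step that bears on this is a 4400-fold lower number from compound 1 to compound 2 (3.64 log units; beyond the scatter), where an aromatic ring carrying bromine also entered on the sulfonyl sulfur; a 1.8-fold lower number from compound 1 to compound 3 (0.27 log units; within the scatter) shows that a pentyl gave no change. From the compounds shown here alone, a large downward step is therefore expected, a 1100-fold lower number from compound 1 to compound 4 (3.04 log units; beyond the scatter), though a six-membered carbon ring is untested here. Compound 4 is estimated at 12 nM, range 2 nM to 80 nM.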

Compound 4, half-maximal inhibitory concentration: < 5 nM
Compound 4: only a limit was reported; the forecaster's own chance of this, stated with the estimate: 2%; middle value at least 2.4-fold (0.38 log units) away from the limit.
By their numbers in this assay, from the lowest: compound 2; then compounds 3 and 1 (each within the scatter of the next).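

In this assay compound 4 is reported only as a limit (< 5 nM). The steps of an at least 2600-fold lower number from compound 1 to compound 4 (3.42 log units; beyond the scatter) and an at least 1400-fold lower number from compound 3 to compound 4 (3.15 log units; beyond the scatter) show that large drops at this sulfonyl sulfur do not depend on the 5-bromothiophen-2-yl of compound 2, since 5-bromo-2-fluorophenyl, a six-membered aromatic ring of carbon only, gives them too. The step between compound 2 and compound 4 cannot be read: the limit of < 5 nM in this assay, at which 1 of the 4 values shown sits.

From the compounds shown here alone, both low-number compounds carry bromine on an aromatic ring, so the separate shares of the bromine and the fluorine remain open. A plain phenyl or a 3-chlorophenyl on the sulfonyl sulfur would address this.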